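Swapping the terminal amine of compound 1 for a carboxylic acid

The compounds below may be only part of what the source reports. "The series", "measured", "known", "first", "only" and "open" are said of these compounds alone.

Measured compounds:
- Compound 1, `CCn1c(C(=O)NCCN)ccc1C(CC)(CC)c1ccc(OCS(=O)(=O)c2ccccc2)c(C)c1`: 6470 nM
- Compound 2, `CCn1c(C(=O)NCCO)ccc1C(CC)(CC)c1ccc(OCS(=O)(=O)c2ccccc2)c(C)c1`: 15500 nM
- Compound 3, `CCn1c(C(=O)N[C@H](CO)C(C)C)ccc1C(CC)(CC)c1ccc(OCS(=O)(=O)c2ccccc2)c(C)c1`: 25500 nM

All three share the same core and differ only in the group attached to the amide nitrogen. In a functional assay on MCF7 cells (Homo sapiens) for antiproliferative activity, read by MTT assay, with a stated time of 24 h (on this read-out higher numbers stand for weaker inhibition and lower numbers for stronger inhibition), compound 1 gives the lowest number of the three, so it is the strongest inhibitor of this small set; the next is compound 2, and compound 3 is furthest away.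

Compound 4, `CCn1c(C(=O)NCC(=O)O)ccc1C(CC)(CC)c1ccc(OCS(=O)(=O)c2ccccc2)c(C)c1`, is the next member. Relative to compound 1 it carries carboxy in place of aminomethyl on a saturated chain carbon bound to an amide-type nitrogen.

Two measured steps start from compound 1 and replace or alter the same 2-aminoethyl group. The first, a 2.4-fold higher number from compound 1 to compound 2 (0.38 log units; beyond the scatter), exchanges the amino for a hydroxy and weakens inhibition modestly. The second, a 3.9-fold higher number from compound 1 to compound 3 (0.60 log units; beyond the scatter), replaces the whole chain and weakens inhibition somewhat more. Both changes that remove the amino end push the number upward, and none of the three compounds goes against that trend. The carboxy in compound 4 likewise removes the amino end, so a step of similar or somewhat larger size in the same direction is expected.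

Compound 4 is therefore estimated at 22000 nM, with a range of 8000 nM to 60000 nM. This expected change corresponds to a 3.4-fold higher number from compound 1 to compound 4 (0.53 log units; beyond the scatter).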

Compound 4, half-maximal inhibitory concentration: 33100 nM
Compound 4: the middle estimate sits 1.5-fold (0.18 log units) below what was measured; the range from low to high includes it.
By their numbers in this assay, from the lowest: compound 1; then compounds 2, 3 and 4 (each within the scatter of the next, the first and the last beyond it).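

In this assay, the carboxy gives the largest step seen so far from the aminomethyl end of compound 1 (a 5.1-fold higher number from compound 1 to compound 4 (0.71 log units; beyond the scatter)), and compound 1 remains the strongest inhibitor of the four, with all three replacements of its chain giving higher numbers and none going against that pattern. The new result also shows that this chain end still matters once the amino is gone: replacing hydroxymethyl with carboxy gives a further modest rise (a 2.1-fold higher number from compound 2 to compound 4 (0.33 log units; beyond the scatter)), while the carboxymethyl and 1-(hydroxymethyl)-2-methylpropyl groups cannot be separated on the amide-type nitrogen (a 1.3-fold higher number from compound 3 to compound 4 (0.11 log units; within the scatter)), so quite different groups can give numbers that are indistinguishable here. No supporting measurement is available to explain the size of these steps.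

The compounds shown leave open whether a longer chain ending in an amine, or a dimethylamino group in place of the amino, would bring the number below that of compound 1. They also leave open whether a methyl ester behaves like the carboxylic acid or whether the gain seen with the amine depends on its distance from the amide-type nitrogen.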